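The compounds below may be only part of what the source reports. "The series", "measured", "known", "first", "only" and "open" are said of these compounds alone.

In a functional assay on KB cells (Homo sapiens) for inhibition, read by MTT assay, with a stated time of 24 h, tested at 1 ug/mL (on this read-out lower numbers stand for less inhibition of growth and higher numbers for more inhibition of growth at the one concentration tested), compound 1 `O=C(CCCCC(S)CCS)NO` gives 10.6% and compound 2 `O=C(CCCCC(S)CCS)Nc1ccccc1` gives 11.6%. These two numbers lie within the scatter of each other, so compound 2 stands level with compound 1. Compound 3 `O=C(CCCCC(S)CCS)Nc1ccccc1Cl` is reported only as "not active" (no number reported), without a number. Compound 4 `O=C(CCCCC(S)CCS)Nc1ccc(F)cc1` differs from compound 2 by fluoro in place of hydrogen on an aromatic carbon. For the measured compounds named here, the single measured step, a number 1 percentage points higher from compound 1 to compound 2 (within the scatter), is a different change, phenyl in place of hydroxy on an amide-type nitrogen, so it only hints at how small steps in this set can be. Going by the values given here, with no measured step for this change, the expected step is a number 1.6 percentage points lower from compound 2 to compound 4 (within the scatter), nothing beyond the scatter. The estimated value for compound 4 is 10%, with an expected range from 2% to 20%.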

Compound 4, percent growth inhibition at one concentration: 8.84%
Beside the measured number, compound 4's estimate is 1.2 percentage points above it; measured number inside the range.
By their numbers in this assay, from the lowest: compounds 4, 1 and 2 (each within the scatter of the next).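

In this assay, fluoro in place of hydrogen on an aromatic carbon, para to a large group, gives a number 2.8 percentage points lower from compound 2 to compound 4 (within the scatter), so this change leaves the read-out level. For the compounds shown here, this is the only step with numbers on both sides that falls on the aromatic ring rather than on the amide nitrogen. No measurement here bears on why the number stays level.

On these data alone, whether a larger group at this same position, such as methoxy, an amine or a carboxylic acid, would move the number beyond the scatter stays open.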